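A few compounds are considered here, and "the series" means these few. Any claim that something is new, unique, unknown or untested is made for them only; others in the source may bear on it.

Compound 2 `CCO/C(O)=C1\C(COCCn2cc(N)nc2O)=NC(C)=C(C(=O)OC)C1c1ccccc1Cl` gives 31.6 nM in a functional assay (aorta) with Rattus norvegicus as the target (on this read-out higher numbers stand for weaker inhibition and lower numbers for stronger inhibition), the highest number of the three in hand; compound 1 `CCO/C(O)=C1\C(COCCn2nncc2C(N)=O)=NC(C)=C(C(=O)OC)C1c1cccc(Cl)c1Cl` gives 15.9 nM, which lies within the scatter of compound 2, whereas compound 3 `CCO/C(O)=C1\C(COCCn2cc(C(N)=O)nn2)=NC(C)=C(C(=O)OC)C1c1cccc(Cl)c1Cl` gives 3.16 nM, a lower number than compound 2 by more than the scatter. Among the measured compounds shown here, the only measured step at this chain position is a 5.0-fold lower number from compound 1 to compound 3 (0.70 log units; beyond the scatter), and it keeps the same aromatic ring throughout. Compound 4 `CCO/C(O)=C1\C(COCCN2CC(=O)N(C)C2=O)=NC(C)=C(C(=O)OC)C1c1ccccc1Cl` differs from compound 2 by 3-methyl-2,4-dioxoimidazolidin-1-yl in place of 4-amino-2-hydroxy-1H-imidazol-1-yl on a saturated chain carbon, two bonds along the chain from an oxygen on a saturated carbon. For the measured compounds named here, no measured step swaps an aromatic ring for a non-aromatic one, so the step from compound 1 to compound 3 bears only loosely and no direction is expected beyond the scatter in this assay this assay. Compound 4 is estimated at 30 nM, within 8 nM to 120 nM, an expected step of a 1.1-fold lower number from compound 2 to compound 4 (0.02 log units; within the scatter).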

Compound 4, half-maximal inhibitory concentration: 25.1 nM
Compound 4: the middle estimate sits 1.2-fold (0.08 log units) above what was measured; measured number inside the range.
By their numbers in this assay, from the lowest: compound 3; then compounds 1, 4 and 2 (each within the scatter of the next).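

In this assay, putting 3-methyl-2,4-dioxoimidazolidin-1-yl in place of 4-amino-2-hydroxy-1H-imidazol-1-yl gives a 1.3-fold lower number from compound 2 to compound 4 (0.10 log units; within the scatter), so this first swap of an aromatic ring for a non-aromatic one at this position leaves the read-out within the scatter. The entering group has 0 hydrogen-bond donors, so for this pair, donors on this group are not needed to hold the read-out at this level. Nothing on hand explains this outcome. On these data alone, it remains open whether a carboxylic acid or a simple amine on this chain carbon stays in the same range, and whether a longer chain does.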